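Opening the three-membered ring of compound 2

The source may hold more compounds than are shown below. What is called first, only, known or untested is meant among the compounds shown, and "the series" means these compounds.

Compound 1 `CN(Cc1ccccc1OCCCCCC(=O)O)C(=O)c1ccc(-c2ccco2)cc1` gives 44 mL/min/kg
Compound 2 `CN(Cc1ccccc1OCCC[C@@H]1C[C@H]1C(=O)O)C(=O)c1ccc(-c2ccco2)cc1` gives 0.6 mL/min/kg

Both numbers come from an ADME assay on the whole organism (strain CD-1) for pharmacokinetics, with Mus musculus as the target, at a dose of 3 mg/kg by the intravenous route (on this read-out lower numbers stand for slow clearance and higher numbers for fast clearance), and compound 2 holds the lower of the two, so it is cleared more slowly. Among the measured compounds shown here, the one measured step (a 73-fold lower number from compound 1 to compound 2 (1.87 log units; beyond the scatter)) came with 2-carboxycyclopropyl in place of 2-carboxyethyl, and it lies well beyond the usual scatter.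

Compound 3 `C/C(=C\COc1ccccc1CN(C)C(=O)c1ccc(-c2ccco2)cc1)CCC(=O)O` has the same atoms as compound 2, joined differently (4-carboxy-2-methylbut-1-en-1-yl in place of 2-(2-carboxycyclopropyl)ethyl on a saturated chain carbon bound to an oxygen on an aromatic ring). The three-membered ring is gone, and an open chain with a double bond stands in its place.

For the measured compounds named here, only that one step bears on this change, and it is thin evidence. Going by the values given here, no measured compound carries the new chain. Compound 3 shares the lack of a ring with compound 1 (44 mL/min/kg), so a return part of the way towards that number is expected. In this assay the expected step (a 25-fold higher number from compound 2 to compound 3 (1.40 log units; beyond the scatter)) is a rise beyond the scatter, smaller than the measured one. Compound 3 is expected at about (15 mL/min/kg), with an estimated range (3 mL/min/kg to 50 mL/min/kg).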

Compound 3, clearance: 15 mL/min/kg
Beside the measured number, compound 3's estimate shows no gap at the digits printed; measured number inside the range.
By their numbers in this assay, from the lowest: compound 2; then compound 3; then compound 1.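

Compound 3 holds the same atoms as compound 2, so the step in this assay of a 25-fold higher number from compound 2 to compound 3 (1.40 log units; beyond the scatter) shows that the way these atoms are joined at this position can by itself move the number far beyond the scatter. The step of a 2.9-fold lower number from compound 1 to compound 3 (0.47 log units; beyond the scatter) shows that removing the three-membered ring does not simply return the number to that of the straight 4-carboxybutyl chain, since two chains without a ring now stand apart by more than the scatter. What lies behind either step cannot be said from these data, as no separate measurement speaks to it.

The new chain brings a methyl branch and a double bond together, so the compounds shown leave open which of the two accounts for its place between the other two compounds. They also leave open how a saturated chain with the methyl branch alone, a chain with the double bond alone, or a four-membered carbon ring in place of the three-membered ring would fall on this read-out.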